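Sulfoximine in place of the carbinol on the aryl ring

The compounds below may be only part of what the source reports. "The series", "measured", "known", "first", "only" and "open" are said of these compounds alone.

Measured so far:
compound 1 `CC#C[C@H]1CN(S(=O)(=O)c2ccc(N)nc2)CCN1c1ccc(S(=O)(=NC)C(F)(F)F)cc1` — 2060 nM
compound 2 `CC#C[C@H]1CN(S(=O)(=O)c2ccc(N)nc2)CCN1c1ccc(S(N)(=O)=O)cc1` — 37 nM
compound 3 `CC#C[C@H]1CN(S(=O)(=O)c2ccc(N)nc2)CCN1c1ccc(C(O)(COC)C(F)(F)F)cc1` — 202 nM

In an assay on cells (Hepatocyte) for inhibition of glucokinase regulatory protein (Mus musculus), with stated times of 20 min and 40 min (on this read-out higher numbers stand for an effect only at larger amounts of compound and lower numbers for an effect already at smaller amounts), compound 3 stands second highest of the three numbers. Its nearest neighbour is compound 2, and the step of a 5.5-fold higher number from compound 2 to compound 3 (0.74 log units; beyond the scatter) is beyond the scatter; the step of a 10-fold lower number from compound 1 to compound 3 (1.01 log units; beyond the scatter) is larger still, so compound 3 sits between the two others and closer to compound 2.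

Compound 4 `CC#C[C@H]1CN(S(=O)(=O)c2ccc(N)nc2)CCN1c1ccc(S(C)(=N)=O)cc1` has not yet been measured in this assay. It differs from compound 3 as follows: a group of 4 heavy atoms (1 carbon, 1 nitrogen, 1 oxygen, 1 sulfur; no ring) in place of a group of 9 heavy atoms (4 carbon, 2 oxygen, 3 fluorine; no ring), on an aromatic carbon. The group that enters is small, with one hydrogen-bond donor and two acceptors, and in this it resembles the group of 4 heavy atoms that gave compound 2 its number. Within the data shown here, two measured steps bear on the change: a 56-fold lower number from compound 1 to compound 2 (1.75 log units; beyond the scatter), where a small four-atom group replaced a larger eight-atom group on the same aromatic carbon, and a 10-fold lower number from compound 1 to compound 3 (1.01 log units; beyond the scatter). Both point the same way, toward lower numbers for smaller, donor-bearing groups at this position.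

The step of a 3.4-fold lower number from compound 3 to compound 4 (0.53 log units; beyond the scatter) is therefore expected to be a modest move to lower numbers, beyond the scatter. For compound 4 the estimate is 60 nM, with a range from 20 nM to 200 nM.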

Compound 4, half-maximal effective concentration: 704 nM
For compound 4 the middle estimate is 12-fold (1.07 log units) below the measured one; the measured number lies above the stated range.
By their numbers in this assay, from the lowest: compound 2; then compound 3; then compound 4; then compound 1.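

In this assay, heavy-atom count alone does not settle this position: a 19-fold higher number from compound 2 to compound 4 (1.28 log units; beyond the scatter), although both groups have 4 heavy atoms and sit on the same aromatic carbon, para to a large group. Nor does a smaller group with the same printed donor and acceptor counts bring a lower number against the carbinol, as a 3.5-fold higher number from compound 3 to compound 4 (0.54 log units; beyond the scatter) shows, so the earlier link between small groups and lower numbers holds for compound 2 but fails for compound 4. The larger sulfoximine gives only part of the gain seen with the sulfonamide, a 2.9-fold lower number from compound 1 to compound 4 (0.47 log units; beyond the scatter), and both sulfoximines keep higher numbers than the sulfonamide and the carbinol.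

Still open, on these data alone, is where a methyl sulfone or a carboxylic acid on this aromatic carbon would fall relative to the sulfonamide and the sulfoximine of compound 4. Nothing in the data available here explains the gap between the sulfonamide and this sulfoximine.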